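Replacing the benzylidene imine in compound 3 with a pyrrolidinylmethylamino group

The compounds below may be only part of what the source reports. "The series", "measured", "known", "first", "only" and "open" are said of these compounds alone.

Compound 3 `N#CC1=C(/N=C/c2ccccc2)N(c2ccccc2)C(=O)N2CCCCC(N3CCCC3)C12` gives 84% in a functional assay on the whole organism (strain albino) for inhibition, with Rattus norvegicus as the target, read by paw edema, with stated times of 1 h and 3 h, at a dose of 20 mmol/kg by the intraperitoneal route (a lower number here means a weaker effect, a higher number a stronger effect of the compound at the dose given), the second highest of the three numbers. Compound 2 `COC(=O)C(=O)NC1=C(C#N)C2C(N3CCCC3)CCCCN2C(=O)N1c1ccccc1` gives 88.3%, and the gap a number 4.3 percentage points lower from compound 2 to compound 3 (within the scatter) is within the scatter; compound 1 `N#CC1=C(NC(=O)c2ccccc2O)N(c2ccccc2)C(=O)N2CCCCC(N3CCCC3)C12` gives 65.4%, and the step of a number 18.6 percentage points higher from compound 1 to compound 3 (beyond the scatter) lies beyond it. Compound 4 `N#CC1=C(NCN2CCCC2)N(c2ccccc2)C(=O)N2CCCCC(N3CCCC3)C12` differs from compound 3 by a group of 7 heavy atoms (5 carbon, 2 nitrogen; one five-membered non-aromatic ring with 1 hetero atom) in place of a group of 8 heavy atoms (7 carbon, 1 nitrogen; one six-membered aromatic ring of carbon only), on a double-bonded ring carbon. The steps of a number 18.6 percentage points higher from compound 1 to compound 3 (beyond the scatter) and a number 4.3 percentage points lower from compound 2 to compound 3 (within the scatter) both vary this same position and show that it tolerates diverse groups with only modest consequences. Compound 4 is therefore expected to stay close to compound 3, with a step of a number 9 percentage points lower from compound 3 to compound 4 (within the scatter) that is within the scatter. Compound 4 is estimated at 75%, between 55% and 92%.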

Compound 4, a percentage reported as inhibition, in the whole organism at one dose (the size of the read-out at that dose, not a potency): 35.3%
The estimate for compound 4 lay 39.7 percentage points above the measured number, outside the stated range (below it).
By their numbers in this assay, from the lowest: compound 4; then compound 1; then compounds 3 and 2 (each within the scatter of the next).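

In this assay, the position on the double-bonded ring carbon proves far less tolerant than the earlier groups suggested: ((pyrrolidin-1-yl)methyl)amino brings a number 48.7 percentage points lower from compound 3 to compound 4 (beyond the scatter). The loss also holds against both acylated amines, with a number 53 percentage points lower from compound 2 to compound 4 (beyond the scatter) and a number 30.1 percentage points lower from compound 1 to compound 4 (beyond the scatter), so this group stands apart from all three earlier ones. Nothing available explains the drop.

The compounds shown leave open whether the loss follows the pyrrolidine ring or the methylene link on the amine nitrogen. A (morpholin-4-yl)methyl group, a longer ethylene link or a plain acetyl group there would help separate the two.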